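Replacing the amide group of compound 3 with cyclopentyl

The source may hold more compounds than are shown below. What is called first, only, known or untested is meant among the compounds shown, and "the series" means these compounds.

In a functional assay on A549 cells (Homo sapiens) for antiproliferative activity, read by MTT assay, with a stated time of 72 h (a higher number here means a weaker inhibitor, a lower number a stronger inhibitor), compound 3 `Cc1noc(C)c1-c1nn(Cc2ccc(C(=O)NC3CCN(C)CC3)cc2)c(=O)c2ccccc12` gives > 100000 nM, which is a limit of the assay and not a number. Compound 4 `Cc1noc(C)c1-c1nn(Cc2ccc(C(=O)NC3CCCC3)cc2)c(=O)c2ccccc12` carries cyclopentyl in place of 1-methylpiperidin-4-yl on an amide-type nitrogen. Within the data shown here, one measured step bears on this place: an at least 1.1-fold higher number from compound 1 to compound 3 (0.06 log units; that floor lies within the scatter). The starting point of that step, compound 1 `Cc1noc(C)c1-c1nn(Cc2ccc(C(=O)N3CCCCC3)cc2)c(=O)c2ccccc12`, gives 86200 nM. The cyclopentylcarbamoyl group also appears in compound 2 `Cn1cc(-c2nn(Cc3ccc(C(=O)NC4CCCC4)cc3)c(=O)c3ccccc23)cn1`, which differs elsewhere in the structure and gives 32300 nM, so a move to a lower number is expected. The estimated step is an at least 2.2-fold lower number from compound 3 to compound 4 (0.34 log units; beyond the scatter). For compound 4 the expected value is 45000 nM, with an estimated range of 15000 nM to 100000 nM.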

Compound 4, half-maximal inhibitory concentration: > 100000 nM
Compound 4: no number, only a limit; the forecaster's own chance of this, stated with the estimate: 20%; middle value at least 2.2-fold (0.34 log units) away from the limit.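

Compound 4 sits at a limit of the assay, not at a number, so cyclopentyl on the amide-type nitrogen does not by itself bring a measurable value. Within this pair the other group decides: 3,5-dimethyl-1,2-oxazol-4-yl in place of 1-methyl-1H-pyrazol-4-yl gives an at least 3.0-fold higher number from compound 2 to compound 4 (0.49 log units; beyond the scatter), while the comparison with the piperidine amide gives only an at least 1.1-fold higher number from compound 1 to compound 4 (0.06 log units; that floor lies within the scatter). The step between compound 3 and compound 4 cannot be read, because both sit at the same limit: the limit of > 100000 nM in this assay, at which 2 of the 4 values shown sit.

Going by these compounds, whether a longer chain or a carboxylic acid on the amide-type nitrogen would bring the number below this limit remains open.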